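A few compounds are considered here, and "the series" means these few. Any claim that something is new, unique, unknown or untested is made for them only; others in the source may bear on it.

Among the compounds with values here, compound 2 `Cc1ccc(S(=O)(=O)NC(=O)Nc2ccccc2C(=O)/C=C/c2cccc([N+](=O)[O-])c2)cc1` gives 44.5 ug/mL in an ADME assay on the whole organism for cytotoxicity, with Artemia salina as the target, with a stated time of 24 h (on this read-out lower numbers stand for an effect already at smaller amounts and higher numbers for an effect only at larger amounts of compound), the higher of the two numbers so far; compound 1 `Cc1ccc(S(=O)(=O)NC(=O)Nc2ccccc2C(=O)/C=C/c2ccc(O)cc2)cc1` gives 24.3 ug/mL. Within the data shown here, the only step between them, a 1.8-fold higher number from compound 1 to compound 2 (0.26 log units; within the scatter), is within the scatter. Compound 3 `Cc1ccc(S(=O)(=O)NC(=O)Nc2ccccc2C(=O)/C=C/c2ccccc2Cl)cc1` is not yet measured; the change is 2-chlorophenyl in place of 3-nitrophenyl on a double-bonded chain carbon bound to a double-bonded chain carbon. Among the measured compounds shown here, the one measured step bearing on this place, a 1.8-fold higher number from compound 1 to compound 2 (0.26 log units; within the scatter), gives no ground for a step beyond the scatter in this assay. Compound 3 is therefore expected to give 35 ug/mL (range 15 ug/mL to 80 ug/mL), an estimated step of a 1.3-fold lower number from compound 2 to compound 3 (0.10 log units; within the scatter).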

Compound 3, concentration for half-maximal effect: 12.8 ug/mL
Compound 3: middle estimate off by 2.7-fold (0.44 log units), on the high side, outside the stated range (below it).
By their numbers in this assay, from the lowest: compounds 3, 1 and 2 (each within the scatter of the next, the first and the last beyond it).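

At this place, on a double-bonded chain carbon bound to a double-bonded chain carbon, the aryl group can now shift the read-out beyond the scatter in this assay: 2-chlorophenyl in place of 3-nitrophenyl gives a 3.5-fold lower number from compound 2 to compound 3 (0.54 log units; beyond the scatter). In place of 4-hydroxyphenyl, 2-chlorophenyl gives only a 1.9-fold lower number from compound 1 to compound 3 (0.28 log units; within the scatter), so only compound 2 and compound 3 stand apart. No measured evidence on these compounds accounts for this step.

Open, on these data alone, is whether the chlorine itself or its place on the ring matters, since each ring differs from the others in both. An unsubstituted phenyl or an amine on the ring would help separate these.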